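The compounds below may be only part of what the source reports. "The series", "measured", "known", "first", "only" and "open" are said of these compounds alone.

In a physicochemical assay for solubility, measured as kinetic solubility (a higher number here means a more soluble compound, a lower number a less soluble compound), two compounds built on a shared core have been measured so far. Compound 1 `Cc1cc2c(Oc3cnc(C(=O)N4CC(C)C4)cn3)cc(C(=O)Nc3cnccn3)cc2o1` gives 49000 nM, and compound 2 `Cc1cc2c(Oc3cnc(C(=O)N4CC5(COC5)C4)cn3)cc(C(=O)Nc3cnccn3)cc2o1` gives 43000 nM. Going by the values given here, these two numbers lie within the scatter of each other, so compound 2 stands level with the only other measured compound.

Compound 3 `Cc1cc2c(Oc3cnc(C(=O)N(C)C)cn3)cc(C(=O)Nc3cnccn3)cc2o1` has not yet been measured. Its structure departs from compound 2 on a carbonyl carbon: a group of 3 heavy atoms (2 carbon, 1 nitrogen; no ring) in place of a group of 7 heavy atoms (5 carbon, 1 nitrogen, 1 oxygen; 2 four-membered non-aromatic rings with 1 hetero atom each), on a carbonyl carbon. Dimethylamino is the group that enters there.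

Among the compounds with values here, one measured step bears on this change, as it also falls on a carbonyl carbon: a 1.1-fold lower number from compound 1 to compound 2 (0.06 log units; within the scatter). That step stayed within the scatter, although the group changed in size and ring count. It is a single step, however, and neither measured compound has a group without a ring at this place, so the evidence is thin. No step beyond the scatter is therefore expected in this assay. The expected step is a 1.1-fold higher number from compound 2 to compound 3 (0.04 log units; within the scatter). The estimate for compound 3 is 47000 nM, with an expected range from 23000 nM to 95000 nM.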

Compound 3, solubility: 30000 nM
Compound 3: the middle estimate sits 1.6-fold (0.19 log units) above what was measured; the measured number falls inside the stated range.
By their numbers in this assay, from the lowest: compounds 3, 2 and 1 (each within the scatter of the next).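

In this assay, going by these compounds alone, dimethylamino on the carbonyl carbon is the first group at this place without a ring, and it gives a 1.4-fold lower number from compound 2 to compound 3 (0.16 log units; within the scatter), while the step measured against 3-methylazetidin-1-yl is a 1.6-fold lower number from compound 1 to compound 3 (0.21 log units; within the scatter). Both steps stay within the scatter, so the three groups now read at this position, from the smallest to the largest and with no ring, one ring or two, are not told apart by this assay, and the earlier single step between two ring-bearing groups could not show that this also holds for a group without a ring. The compounds shown carry nothing that accounts for the numbers at this position, and no other measurement bears on them.

From the compounds shown here alone, what stays open is whether a group of another kind on this carbonyl carbon, such as a piperazine with a free amine, a carboxylic acid or a longer chain, would also remain within the scatter of these three compounds. Also unresolved is whether the same holds when the shared core is changed elsewhere, since all three compounds carry the same core and differ only at this one place.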